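From a Ring to a Long Chain on the Ester

A few compounds are considered here, and "the series" means these few. Any claim that something is new, unique, unknown or untested is made for them only; others in the source may bear on it.

For the measured compounds named here, compound 3 `CO[C@@H](C(=O)NC1CC[C@@H](OC(=O)CC2CCCCC2)CNC1=O)[C@H](O)[C@@H](O)[C@H](O)/C=C/C(C)(C)C` stands second highest of the three numbers so far in an in vivo functional assay on the whole organism (MDA-MB-435 cells, Homo sapiens) for antiproliferative activity (on this read-out higher numbers stand for weaker inhibition and lower numbers for stronger inhibition), giving 60 nM. Compound 1 `CCCCCc1ccc(C(=O)O[C@@H]2CCC(NC(=O)[C@H](OC)[C@H](O)[C@@H](O)[C@H](O)/C=C/C(C)(C)C)C(=O)NC2)cc1` gives 20 nM, and compound 2 `CO[C@@H](C(=O)NC1CC[C@@H](OC(=O)Cc2cccnc2)CNC1=O)[C@H](O)[C@@H](O)[C@H](O)/C=C/C(C)(C)C` gives 5850 nM. Compound 4 `CCCCCCCCCCCCCC(=O)O[C@@H]1CCC(NC(=O)[C@H](OC)[C@H](O)[C@@H](O)[C@H](O)/C=C/C(C)(C)C)C(=O)NC1` differs from compound 3 in one place: dodecyl in place of cyclohexyl on a saturated chain carbon bound to a carbonyl carbon. Going by the values given here, two measured steps bear on this change. The step of a 98-fold lower number from compound 2 to compound 3 (1.99 log units; beyond the scatter) shows that swapping pyridin-3-yl for a carbon-only cyclohexyl lowered the number greatly, while the step of a 3.0-fold higher number from compound 1 to compound 3 (0.48 log units; beyond the scatter) shows that cyclohexylmethyl and 4-pentylphenyl give numbers only modestly apart. Dodecyl, like those two groups, is built of carbon only, so the step expected for a 2.0-fold lower number from compound 3 to compound 4 (0.30 log units; within the scatter) is small, at most modest. Compound 4 is therefore expected to give about 30 nM, within a range from 8 nM to 120 nM.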

Compound 4, half-maximal inhibitory concentration: < 10 nM
Compound 4: no number, only a limit (the forecaster's own chance of this, stated with the estimate: 2%); at least 3.0-fold (0.47 log units) between middle value and limit.
By their numbers in this assay, from the lowest: compound 1; then compound 3; then compound 2. At a limit, below all of these: compound 4.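

Compound 4 gives no exact number in this assay, only a limit: the limit of < 10 nM in this assay, at which 1 of the 4 values shown sits. Even so, this position clearly accepts a long open chain with no ring, since dodecyl in place of cyclohexyl brings an at least 6.0-fold lower number from compound 3 to compound 4 (0.77 log units; beyond the scatter). Set against the pyridin-3-yl ester, dodecyl gives an at least 580-fold lower number from compound 2 to compound 4 (2.76 log units; beyond the scatter), the widest gap seen so far at this position.

On these data alone, how much of this gain depends on the full length of the chain remains open. So does whether a shorter octyl chain, or a dodecyl chain ending in an amine or a carboxylic acid, would keep it.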